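This account rests on a few compounds, and the source may have more. Where it says the series, first, only, none or still open, it means among the compounds named here.

In a functional assay on K562 cells (Homo sapiens) for antiproliferative activity, read by MTT assay, with a stated time of 6 days (a lower number here means a stronger inhibitor, a higher number a weaker inhibitor), compound 3 `O=C1C=C[C@@H](OCc2ccccc2)[C@@H]([C@@H](COC(=O)/C=C/c2ccccc2)OCc2ccccc2)O1` gives 1590 nM, the lowest of the three numbers recorded so far. Among the compounds with values here, compound 1 `CC(=O)O[C@@H]1C=CC(=O)O[C@@H]1[C@@H](COC(=O)c1ccc(Cl)cc1)OC(C)=O` gives 3690 nM and compound 2 `CC(=O)O[C@@H]1C=CC(=O)O[C@@H]1[C@@H](COC(=O)c1ccc([N+](=O)[O-])cc1)OC(C)=O` gives 7640 nM; the only one-place step between measured compounds, a 2.1-fold higher number from compound 1 to compound 2 (0.32 log units; beyond the scatter), alters a different aromatic ring from the one changed here, so it bears on the present step only loosely. Compound 4 `COc1ccc(/C=C/C(=O)OC[C@@H](OCc2ccccc2)[C@H]2OC(=O)C=C[C@H]2OCc2ccccc2)cc1` differs from compound 3 by methoxy in place of hydrogen on an aromatic carbon, that is, a methoxy in place of hydrogen on an aromatic carbon. Within the data shown here, no measured step adds a methoxy, and the step to compound 4 is therefore expected to remain within the scatter, a 1.0-fold higher number from compound 3 to compound 4 (0.00 log units; within the scatter). Compound 4 is estimated at 1600 nM, with a range from 700 nM to 3700 nM.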

Compound 4, half-maximal inhibitory concentration: 430 nM
For compound 4 the middle estimate is 3.7-fold (0.57 log units) above the measured one, outside the stated range (below it).
By their numbers in this assay, from the lowest: compound 4; then compound 3; then compound 1; then compound 2.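

In this assay, methoxy in place of hydrogen on the aromatic ring of the 2-phenylethenyl group, para to a large group, gives a 3.7-fold lower number from compound 3 to compound 4 (0.57 log units; beyond the scatter). Within the data shown here, this is the first measured change on this ring, and it shows that the number responds to a substituent at this position, which the earlier compounds did not show. Nothing available accounts for the step. The compounds shown leave open whether a hydroxyl or an amine at the same position would move the number in the same direction.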